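The source may report more compounds than this note shows. Statements on the series, on what has been measured and on what is new or still open speak of the compounds shown alone.

The compounds in view here share one core. Compound 2 `COC(=O)CNc1c(C(=O)NCc2ccc(F)cc2)nc(Br)c2cccnc12` and compound 3 `CNCCCNc1c(C(=O)NCc2ccc(F)cc2)nc(Br)c2cccnc12` have been measured in a functional assay on LNCaP cells (Homo sapiens) for cytotoxicity, read by MTT assay, with a stated time of 72 h (on this read-out lower numbers stand for stronger inhibition and higher numbers for weaker inhibition), where compound 2 gives 5000 nM and compound 3 gives 8000 nM. Compound 1 `N[C@H]1CC[C@H](Nc2c(C(=O)NCc3ccc(F)cc3)nc(N3CCCCC3)c3cccnc23)CC1` carries a different group on its core; in this assay compound 1 gives "not determined" (no result reported). Among the two numbers, compound 3 stands highest, but the step between them is a 1.6-fold higher number from compound 2 to compound 3 (0.20 log units; within the scatter), which is within the scatter, so the two compounds cannot be told apart on this evidence.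

Compound 4 `N[C@H]1CC[C@H](Nc2c(C(=O)NCc3ccc(F)cc3)nc(Br)c3cccnc23)CC1` is the next step from compound 3. The change is 4-aminocyclohexyl in place of 3-(methylamino)propyl on a nitrogen on an aromatic ring. For the measured compounds named here, the only measured step that touches the same position is the one from compound 2 to compound 3, and that step was a 1.6-fold higher number from compound 2 to compound 3 (0.20 log units; within the scatter), within the scatter. One step at one position is slender evidence, and the entering group with its ring and two stereocentres is of a new kind, yet nothing measured points to a large movement either way. The step expected from compound 3 to compound 4 is therefore a 1.3-fold lower number from compound 3 to compound 4 (0.12 log units; within the scatter), not beyond the scatter. Compound 4 is thus expected to show 6000 nM in this assay, with a range from 2500 nM to 15000 nM.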

Compound 4, half-maximal inhibitory concentration: 5000 nM
Estimate against measurement, compound 4: 1.2-fold (0.08 log units) above; the measured number falls inside the stated range.
By their numbers in this assay, from the lowest: compounds 2, 4 and 3 (each within the scatter of the next).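

Placing a ring at this position is the new information: in this assay 4-aminocyclohexyl in place of 3-(methylamino)propyl gives a 1.6-fold lower number from compound 3 to compound 4 (0.20 log units; within the scatter) and the same group in place of (methoxycarbonyl)methyl gives no change at the digits printed from compound 2 to compound 4 (within the scatter) on the shared core. On a nitrogen on an aromatic ring, then, a six-membered non-aromatic ring of carbon with 2 defined stereocentres cannot be told apart from either open chain, and compound 2, compound 3 and compound 4 form one group with no order that this read-out can support. Nothing shown explains why such different groups give numbers this close.

Compound 1 carries the same 4-aminocyclohexyl with a different group in place of the bromine, but compound 1 gives "not determined" (no result reported) in this assay so what that other place contributes cannot be read. Also open, as far as these compounds go, is whether a carboxylic acid, a longer amine chain or a phenyl ring on this nitrogen would give a number that stands clear of these three.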